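A few compounds are considered here, and "the series" means these few. Any claim that something is new, unique, unknown or untested is made for them only; others in the source may bear on it.

Compound 1 `CSc1nc(NCCCNc2ccnc3cc(Cl)ccc23)c(C#N)c(-c2ccccc2)n1` and compound 2 `CSc1nc(NCCCCNc2ccnc3cc(Cl)ccc23)c(C#N)c(-c2ccccc2)n1` share a core and differ only in the length of the linking chain. In an ADME assay on CCRF-CEM cells (Homo sapiens) for inhibition, read by cell counting (on this read-out lower numbers stand for stronger inhibition and higher numbers for weaker inhibition), compound 1 gives 4700 nM, and compound 2 gives 5200 nM; compound 2 holds the highest of the two numbers, and its gap to compound 1 lies within the scatter. Compound 3 `CSc1nc(NCCCCNc2ccnc3cc(Cl)ccc23)c(C#N)c(-c2cccc([N+](=O)[O-])c2)n1` differs from compound 2 by nitro in place of hydrogen on an aromatic carbon. Among the compounds with values here, no measured pair shows this change, so the step from compound 2 to compound 3 is expected to stay within the scatter, as a 1.0-fold lower number from compound 2 to compound 3 (0.02 log units; within the scatter). Compound 3 is therefore estimated at 5000 nM, between 2000 nM and 12000 nM.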

Compound 3, half-maximal inhibitory concentration: 2100 nM
Estimate against measurement, compound 3: 2.4-fold (0.38 log units) above; low and high end bracket the measured number.
By their numbers in this assay, from the lowest: compound 3; then compounds 1 and 2 (each within the scatter of the next).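

In this assay, going from phenyl to 3-nitrophenyl gives a 2.5-fold lower number from compound 2 to compound 3 (0.39 log units; beyond the scatter), so this aromatic ring responds to a substitution, whereas the two chain lengths of compound 1 and compound 2 stayed within the scatter of each other. Nothing at hand accounts for this step. The compounds shown leave open whether an amine or a carboxylic acid on this ring would lower the number as nitro does, and whether another place on the ring would serve equally. They also leave open whether nitro acts the same way on the shorter chain of compound 1.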